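Notes on the step from compound 2 to compound 4

The compounds below may be only part of what the source reports. "The series", "measured", "known", "first", "only" and "open" are said of these compounds alone.

Measured in a functional assay on BT-549 cells (Homo sapiens) for inhibition, read by sulforhodamine B assay, with a stated time of 48 h (a higher number here means that more compound is tolerated, a lower number that less compound is tolerated), with each value a limit of the assay:
- compound 1 `O=C(Nc1cccc(-n2cc(-c3ccncc3)c(-c3ccc(Cl)c(O)c3)n2)c1)Nc1cccc(C(F)(F)F)c1` gives > 32500 nM as a limit
- compound 2 `COc1cc(-c2nn(-c3cccc(NC(=O)c4cccc(C(F)(F)F)c4)c3)cc2-c2ccncc2)ccc1Cl` gives > 50000 nM as a limit
- compound 3 `COc1cc(-c2nn(-c3cccc(NC(=O)c4ccc(Cl)c(C(F)(F)F)c4)c3)cc2-c2ccncc2)ccc1Cl` gives > 32500 nM as a limit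

Compound 2 gives > 50000 nM as a limit and has no number to place it. The other two compounds also have limits only, so no order among the three can be read.

Compound 4 `COc1cc(-c2nn(-c3cccc(NC(=O)Nc4ccc(Cl)c(C(F)(F)F)c4)c3)cc2-c2ccncc2)ccc1Cl` differs from compound 2 in one place ((4-chloro-3-(trifluoromethyl)phenyl)amino in place of 3-(trifluoromethyl)phenyl on a carbonyl carbon). For the measured compounds named here, one measured step bears on the chloro part of this change, a step that the two limits leave unreadable from compound 2 to compound 3 and so it offers no size to carry over. Going by the values given here, no measured step covers the amino part that enters on the carbonyl carbon.

Compound 1 likewise remains a limit at > 32500 nM in these notes. No step beyond the scatter is therefore expected in this assay and a further limit is the most likely report. The expected step is an at least 1.2-fold lower number from compound 2 to compound 4 (0.09 log units; that floor lies within the scatter) as estimated here. Compound 4 is estimated at 40000 nM with an expected range of 15000 nM to 65000 nM in this read-out.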

Compound 4, concentration lethal to 50% of the cells: > 32500 nM
Compound 4: a limit, no number; the forecaster's own chance of this, stated with the estimate: 75%; the middle value does not contradict the limit.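

In this assay compound 4 gives > 32500 nM, which is a limit and not a number. The steps to compound 4 from compound 2 and from compound 3 cannot be read, as all three values are limits. Still open is whether any change among these compounds shifts the read-out at all, with the most frequent result being: the limit of > 32500 nM in this assay, at which 3 of the 4 values shown sit.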